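Removing the Methyl From the Aryl Carbamate of Compound 3

The source may hold more compounds than are shown below. What is called first, only, known or untested is meant among the compounds shown, and "the series" means these compounds.

Of the compounds shown here, three sharing one core have been measured in a functional assay on CCRF-CEM cells (Homo sapiens) for cytotoxicity, read by MTT assay, with a stated time of 72 h; on this read-out lower numbers stand for higher toxicity in this test and higher numbers for lower toxicity in this test. Compound 1 `CCCOC(=O)Nc1ccc([Se]C#N)cc1` gives 68800 nM. Compound 2 `CCCCCCOC(=O)Nc1ccc([Se]C#N)cc1` gives 72700 nM. Compound 3 `Cc1ccc(OC(=O)Nc2ccc([Se]C#N)cc2)cc1` gives 72000 nM. Within the data shown here, the only step between compounds that differ in a single place is a 1.1-fold higher number from compound 1 to compound 2 (0.02 log units; within the scatter), a propyl in place of hydrogen on a saturated chain carbon, three bonds along the chain from an oxygen next to a carbonyl group. Among the three numbers compound 3 stands second highest, with compound 2 nearest and compound 1 furthest, both within the scatter.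

Compound 4 `N#C[Se]c1ccc(NC(=O)Oc2ccccc2)cc1` has not yet been measured. It differs from compound 3 by hydrogen in place of methyl on an aromatic carbon, on an aromatic carbon of a six-membered aromatic ring of carbon only, para to a large group. Among the measured compounds shown here, no measured step touches that ring, and the one step that exists, a 1.1-fold higher number from compound 1 to compound 2 (0.02 log units; within the scatter), stayed within the scatter, so in this assay no step beyond the scatter is expected for no change at the digits printed from compound 3 to compound 4 (within the scatter). Compound 4 is therefore estimated at 72000 nM, with a range from 36000 nM to 144000 nM.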

Compound 4, concentration lethal to 50% of the cells: 73200 nM
Compound 4: the middle estimate sits 1.0-fold (0.01 log units) below what was measured; low and high end bracket the measured number.
By their numbers in this assay, from the lowest: compounds 1, 3, 2 and 4 (each within the scatter of the next).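

In this assay, among these compounds, hydrogen in place of methyl on an aromatic carbon gives a 1.0-fold higher number from compound 3 to compound 4 (0.01 log units; within the scatter) so this ring position, which no earlier step touched, shows no difference beyond the scatter for this change. The unsubstituted compound also allows direct comparison with the chains: phenyl in place of hexyl gives a 1.0-fold higher number from compound 2 to compound 4 (0.00 log units; within the scatter) and phenyl in place of propyl gives a 1.1-fold higher number from compound 1 to compound 4 (0.03 log units; within the scatter) so phenyl and these two chains read alike in this test.

Still open, on these data alone, is whether a different group at that ring position, such as an amine or a carboxylic acid, would move the number beyond the scatter. Also open, as far as these compounds go, is whether a change to the shared core would do so, since all four compounds keep it. No evidence on the cause of these close values is at hand.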